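Extending the Aryl Ring of an mGlu2 Positive Modulator

A few compounds are considered here, and "the series" means these few. Any claim that something is new, unique, unknown or untested is made for them only; others in the source may bear on it.

Compound 1 `CC(C)CCn1ccc(-c2ccccc2)c(C#N)c1=O` carries a phenyl ring on its core. In a functional assay on CHO cells for positive allosteric modulation of metabotropic glutamate receptor 2 (Homo sapiens), read by scintillation counting and GTPgammaS binding, with a stated time of 30 min (a lower number here means a smaller maximal response, a higher number a larger maximal response), compound 1 gives 117%, the lowest of the three numbers measured; its nearest neighbour is compound 2 and its furthest is compound 3. Compound 2 `COc1ccccc1-c1ccn(CCC(C)C)c(=O)c1C#N` adds a methoxy group to the phenyl ring and gives 120%, and the step of a number 3 percentage points higher from compound 1 to compound 2 (within the scatter) is within the scatter. Among the compounds with values here, compound 3 `COc1ccc(-c2ccn(CCC(C)C)c(=O)c2C#N)cc1OC` carries two methoxy groups on that ring and gives 242%; no single step links it to compound 1, but the two values show a much larger maximal response for compound 3.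

Compound 4 `CC(C)CCn1ccc(-c2ccc(Oc3ccccn3)cc2)c(C#N)c1=O` differs from compound 1 in one place: (pyridin-2-yl)oxy in place of hydrogen on an aromatic carbon. Within the data shown here, the only measured step that bears on it is the methoxy addition of compound 2, which stayed within the scatter, whereas the larger substitution of compound 3 coincides with a far larger response. A group entering elsewhere on the phenyl ring could go either way, so a moderate rise in this assay is expected, with wide uncertainty. The step of a number 48 percentage points higher from compound 1 to compound 4 (beyond the scatter) is my estimate. Compound 4 is expected to give 165%, within a range from 105% to 250%.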

Compound 4, largest response reached (Emax), in percent of the reference or control that the assay uses: 249%
The estimate for compound 4 lay 84 percentage points below the measured number, within the range that was stated.
By their numbers in this assay, from the lowest: compounds 1 and 2 (each within the scatter of the next); then compounds 3 and 4 (each within the scatter of the next).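

In this assay, (pyridin-2-yl)oxy in place of hydrogen, on an aromatic carbon para to a large group, gives a number 132 percentage points higher from compound 1 to compound 4 (beyond the scatter) and so shows that this carbon can carry a group of 7 heavy atoms, with its own aromatic ring, and still give a much larger maximal response. Within the data shown here, it also shows that an addition to this ring can shift the number well beyond the scatter, which the only earlier single change, methoxy in place of hydrogen with a number 3 percentage points higher from compound 1 to compound 2 (within the scatter) on another carbon of the ring, did not show. No measurement available here explains why the maximal response rises so far. 

The compounds shown leave open which part of the new group goes with the rise: whether a plain phenoxy group, which lacks the ring nitrogen, or a benzyloxy group, which has a longer link, would give a similar number on the same carbon. They also leave open how a small group such as fluorine, or a charged one such as a carboxylic acid, would behave at this position.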